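The compounds below may be only part of what the source reports. "The series", "measured", "known", "first", "only" and "open" are said of these compounds alone.

Compound 1 `O=C1/C(=C/c2cccnc2)CN(S(=O)(=O)c2ccc([N+](=O)[O-])cc2)C/C1=C\c1ccccc1C(F)(F)F` is the reference point of this small set. In a functional assay on QGY-7703 cells (Homo sapiens) for cytotoxicity, read by MTT assay, with a stated time of 24 h (a lower number here means a stronger inhibitor, a higher number a weaker inhibitor), compound 1 gives 7660 nM. For the measured compounds named here, compound 2 `O=C1/C(=C/c2cccnc2)CN(S(=O)(=O)c2ccc(C(F)(F)F)cc2)C/C1=C\c1ccccc1C(F)(F)F` carries the change trifluoromethyl in place of nitro on an aromatic carbon and in this assay compound 2 gives 1500 nM, so the step of a 5.1-fold lower number from compound 1 to compound 2 (0.71 log units; beyond the scatter) is the one change here that moves the number beyond the scatter.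

Compound 3 `O=C1/C(=C/c2ccncc2)CN(S(=O)(=O)c2ccc([N+](=O)[O-])cc2)C/C1=C\c1ccccc1C(F)(F)F` differs from compound 1 only in the core, by pyridin-4-yl in place of pyridin-3-yl on a double-bonded chain carbon bound to a double-bonded ring carbon. In this assay compound 3 gives 9730 nM, and the step of a 1.3-fold higher number from compound 1 to compound 3 (0.10 log units; within the scatter) stays within the scatter, so the two cores cannot be told apart on these numbers.

Compound 4 `O=C1/C(=C/c2ccncc2)CN(S(=O)(=O)c2ccc(C(F)(F)F)cc2)C/C1=C\c1ccccc1C(F)(F)F` is not yet measured. It stands to compound 3 as compound 2 stands to compound 1: the change trifluoromethyl in place of nitro on an aromatic carbon is the same change as trifluoromethyl in place of nitro on an aromatic carbon, made on the core of compound 3, with the same place line on both. Going by the values given here, since the cores themselves did not separate in a 1.3-fold higher number from compound 1 to compound 3 (0.10 log units; within the scatter), the step from compound 3 to compound 4 in this assay is expected to be about a 4.9-fold lower number from compound 3 to compound 4 (0.69 log units; beyond the scatter), resting on the single earlier step of a 5.1-fold lower number from compound 1 to compound 2 (0.71 log units; beyond the scatter). Compound 4 is therefore estimated at 2000 nM, with a range of 900 nM to 4500 nM.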

Compound 4, half-maximal inhibitory concentration: 4680 nM
Compound 4: the middle estimate sits 2.3-fold (0.37 log units) below what was measured; measured number outside the range, above it.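

In this assay, trifluoromethyl in place of nitro again gives a lower number on the second core, a 2.1-fold lower number from compound 3 to compound 4 (0.32 log units; beyond the scatter), and the two steps cannot be told apart: the same change on two cores in this assay, a 5.1-fold lower number (0.71 log units; beyond the scatter) from compound 1 to compound 2 and a 2.1-fold lower number (0.32 log units; beyond the scatter) from compound 3 to compound 4, 2.5-fold (0.39 log units) apart, within the scatter of two such steps

The core change, within the scatter on the nitro pair, reads a 3.1-fold higher number from compound 2 to compound 4 (0.49 log units; beyond the scatter) on the trifluoromethyl pair, yet these two readings cannot be told apart either: the same change on two cores in this assay, a 1.3-fold higher number (0.10 log units; within the scatter) from compound 1 to compound 3 and a 3.1-fold higher number (0.49 log units; beyond the scatter) from compound 2 to compound 4, 2.5-fold (0.39 log units) apart, within the scatter of two such steps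

The direction of the nitro to trifluoromethyl change therefore carries between these two cores, but with one pair on each core the data neither show that its size depends on the core nor establish that the size is the same on both.

On these data alone, it remains open how a nitrile, a methoxy group or an amine would compare with nitro and trifluoromethyl at this place on the aromatic ring. As far as these compounds go, it also remains open whether the same pattern would hold with a plain phenyl in place of the pyridinyl group.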